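Swapping chloro for hydroxy on a cytotoxic lipid-like imine

The source may report more compounds than this note shows. Statements on the series, on what has been measured and on what is new or still open speak of the compounds shown alone.

Measured so far in a functional assay on cells (Homo sapiens) for cytotoxicity, read by MTT assay, with a stated time of 24 h; on this read-out lower numbers stand for stronger inhibition and higher numbers for weaker inhibition:
- compound 1 `CCCCCCCCCCCCCCNC(=O)[C@H](CO)/N=C/c1cccc(C)c1`: 82900 nM
- compound 2 `CCCCCCCCCCCCCCNC(=O)[C@H](CO)NCc1ccccc1O`: 75300 nM
- compound 3 `CCCCCCCCCCCCCCNC(=O)[C@H](CO)/N=C/c1ccccc1Cl`: 10300 nM

Compound 3 has the lowest number of the three, so it is the most strongly cytotoxic here. Its steps to both others lie beyond the scatter, while a 1.1-fold lower number from compound 1 to compound 2 (0.04 log units; within the scatter) shows no real difference.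

The next compound is compound 4 `CCCCCCCCCCCCCCNC(=O)[C@H](CO)/N=C/c1ccccc1O`. The change is hydroxy in place of chloro on an aromatic carbon, ortho to a large group.

For the measured compounds named here, no measured pair makes exactly this swap, so the evidence is indirect. Changing only the ring group on the double-bonded link gave an 8.0-fold lower number from compound 1 to compound 3 (0.91 log units; beyond the scatter). The only measured ring with a hydroxy is the 2-hydroxyphenyl of compound 2, which has a saturated link instead, and that comparison gives a 7.3-fold lower number from compound 2 to compound 3 (0.86 log units; beyond the scatter). Both steps favour compound 3, though the second also includes the change of link.

In this assay, a modest rise in the number is therefore expected, smaller than those two steps, and a 2.9-fold higher number from compound 3 to compound 4 (0.46 log units; beyond the scatter) is the estimated step. For compound 4 the estimated value is 30000 nM, with an expected range of 9000 nM to 90000 nM.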

Compound 4, half-maximal inhibitory concentration: 19000 nM
Compound 4: the middle estimate sits 1.6-fold (0.20 log units) above what was measured; low and high end bracket the measured number.
By their numbers in this assay, from the lowest: compounds 3 and 4 (each within the scatter of the next); then compounds 2 and 1 (each within the scatter of the next).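

In this assay, on this aromatic carbon, ortho to a large group, hydroxy and chloro cannot be told apart (a 1.8-fold higher number from compound 3 to compound 4 (0.27 log units; within the scatter)), so the position tolerates either group, at least on the double-bonded link. For the compounds shown here, with the 2-hydroxyphenyl ring held the same, the double-bonded link gives a lower number than the saturated link (a 4.0-fold lower number from compound 2 to compound 4 (0.60 log units; beyond the scatter)), which is the first comparison to isolate the link from the ring group. On the double-bonded link, 2-hydroxyphenyl also gives a lower number than 3-methylphenyl (a 4.4-fold lower number from compound 1 to compound 4 (0.64 log units; beyond the scatter)), although that swap changes both the group and where it sits on the ring.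

No measurement here bears on the cause of these steps. From the compounds shown here alone, it remains open whether a methoxy or an amine on the same aromatic carbon would stay level with hydroxy and chloro, and whether 2-methylphenyl would separate the effect of the methyl group from that of its place on the ring.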